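The source may report more compounds than this note shows. Statements on the series, on what has been measured and on what is new or still open speak of the compounds shown alone.

Working notes on the series.

The shared core is carried by compound 1 `CCc1cc(=O)c2ccc(OC)c(CBr)c2o1` and compound 2 `COc1ccc2c(=O)cc(C(C)Br)oc2c1CBr`. In a functional assay on KB cells (Homo sapiens) for antiproliferative activity, read by sulforhodamine B assay, with a stated time of 72 h (on this read-out lower numbers stand for stronger inhibition of growth and higher numbers for weaker inhibition of growth), compound 1 gives only a limit, > 33600 nM, which is the limit of > 33600 nM in this assay, at which 1 of the 2 values shown sits. In this assay, among the compounds with values here, compound 2 gives 15100 nM, the only number in the set so far, so compound 2 is the one measured anchor. Within the data shown here, the one step available, an at least 2.2-fold lower number from compound 1 to compound 2 (0.34 log units; beyond the scatter), is the addition of a bromo group on the chain and has no bearing on a change at the ether oxygen.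

Compound 3 `CC(C)Oc1ccc2c(=O)cc(C(C)Br)oc2c1CBr` differs from compound 2 by isopropyl in place of methyl on an oxygen on an aromatic ring; the same difference, cut one bond further out, reads methoxy to isopropoxy. Among the measured compounds shown here, no measured pair changes the group on that oxygen, so there is nothing to scale the step from. Compound 3 is therefore expected to sit close to compound 2, with an expected step of a 1.0-fold lower number from compound 2 to compound 3 (0.00 log units; within the scatter) that is not beyond the scatter. The estimate for compound 3 in this assay is 15000 nM, within a range from 6000 nM to 40000 nM.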

Compound 3, concentration for 50% growth inhibition: 12800 nM
Beside the measured number, compound 3's estimate is 1.2-fold (0.07 log units) above it; the range from low to high includes it.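

In this assay, within the data shown here, the change from methoxy to isopropoxy gives a 1.2-fold lower number from compound 2 to compound 3 (0.07 log units; within the scatter), the first reading of any change at an oxygen on an aromatic ring. Compound 2 and compound 3 cannot be told apart in this assay, so isopropyl, with 3 heavy atoms, takes the place of methyl, with 1 heavy atom, without a difference that the read-out can resolve at this place. Nothing shown here accounts for this step, and the single pair gives no trend for the group on that oxygen.

On these data alone, whether the same holds for other groups on that oxygen stays open, for instance a free hydroxyl, a longer chain such as n-butyl, a benzyl group or a chain ending in an amine. Compound 1 gives only a limit, > 33600 nM, so the same change on a compound with hydrogen in place of the chain bromo has no number to start from in this assay.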